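The compounds below may be only part of what the source reports. "The series", "measured", "known", "first", "only" and "open" are said of these compounds alone.

Within the data shown here, compound 3 `CCn1cc(-c2nc3ccc([N+](=O)[O-])cc3s2)c(=O)c2cc(F)c(N3CCNCC3)cc21` gives the lowest of the three numbers so far in a functional assay on KB cells (Homo sapiens) for cytotoxicity, read by MTT assay, with a stated time of 48 h (on this read-out lower numbers stand for stronger inhibition and higher numbers for weaker inhibition), at 700 nM. Its nearest neighbour is compound 2 `CCn1cc(-c2nc3ccccc3s2)c(=O)c2cc(F)c(N3CCN(C)CC3)cc21`, which in this assay gives 19000 nM, and the parent of the set, compound 1 `CCn1cc(-c2nc3ccccc3s2)c(=O)c2cc(F)c(N3CCNCC3)cc21`, gives 28700 nM in this assay. Among the measured compounds shown here, the single change from compound 1 to compound 3, nitro in place of hydrogen on an aromatic carbon, is a 41-fold lower number from compound 1 to compound 3 (1.61 log units; beyond the scatter).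

Compound 4 `CCn1cc(-c2nc3ccc([N+](=O)[O-])cc3s2)c(=O)c2cc(F)c(N3CCN(C)CC3)cc21` differs from compound 3 by methyl in place of hydrogen on an amine nitrogen in a ring. Exactly this change has been seen once before, from compound 1 to compound 2, where it produced a 1.5-fold lower number from compound 1 to compound 2 (0.18 log units; within the scatter). For the measured compounds named here, no other measured step bears on it. On that basis no shift beyond the scatter is expected in this assay for compound 4, with at most a slight lowering of the number in line with the earlier pair. Compound 4 is therefore expected to give about 550 nM in this assay, within a range from 230 nM to 1400 nM, an estimated step of a 1.3-fold lower number from compound 3 to compound 4 (0.10 log units; within the scatter).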

Compound 4, half-maximal inhibitory concentration: 5800 nM
The estimate for compound 4 lay 11-fold (1.02 log units) below the measured number; measured number outside the range, above it.
By their numbers in this assay, from the lowest: compound 3; then compound 4; then compounds 2 and 1 (each within the scatter of the next).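

In this assay, the change from piperazin-1-yl to 4-methylpiperazin-1-yl is no longer silent on the nitro-bearing core: it gives an 8.3-fold higher number from compound 3 to compound 4 (0.92 log units; beyond the scatter), so what methyl does on this ring nitrogen depends on the core that carries it: the same change on two cores in this assay, a 1.5-fold lower number (0.18 log units; within the scatter) from compound 1 to compound 2 and an 8.3-fold higher number (0.92 log units; beyond the scatter) from compound 3 to compound 4, 13-fold (1.10 log units) apart, beyond the scatter of two such steps

The nitro group likewise gains less once that nitrogen carries methyl, giving only a 3.3-fold lower number from compound 2 to compound 4 (0.52 log units; beyond the scatter), and its effect therefore depends on the group at the ring nitrogen: the same change on two cores in this assay, a 41-fold lower number (1.61 log units; beyond the scatter) from compound 1 to compound 3 and a 3.3-fold lower number (0.52 log units; beyond the scatter) from compound 2 to compound 4, 13-fold (1.10 log units) apart, beyond the scatter of two such steps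

Across these four compounds the two changes do not add up, and the lowest number stays with compound 3, which pairs nitro with the hydrogen on the ring nitrogen.

As far as these compounds go, whether a longer chain such as ethyl, or an acetyl group, on that nitrogen would follow methyl remains open. So does whether an amine or a nitrile in place of nitro on the aromatic carbon would show the same dependence, and the compounds shown give no explanation for it.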